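Morpholin-4-yl in place of benzyloxy at the carbonyl

This account rests on a few compounds, and the source may have more. Where it says the series, first, only, none or still open, it means among the compounds named here.

Measured so far:
compound 1 `CC(C)OC(=O)Nc1cccc(-c2ccc(N(C)C)cc2)c1` — 69%
compound 2 `CN(C)c1ccc(-c2cccc(NC(=O)OCc3ccccc3)c2)cc1` — 50%

In an assay on COS-7 cells for inhibition of patatin-like phospholipase domain-containing protein 2 (Mus musculus), tested at 200 uM (on this read-out higher numbers stand for more inhibition at the one concentration tested (going by the name of the read-out) and lower numbers for less inhibition), compound 2 stands lowest of the two numbers; compound 1 is its nearest neighbour, and the step of a number 19 percentage points lower from compound 1 to compound 2 (beyond the scatter) is beyond the scatter. Compound 3 `CN(C)c1ccc(-c2cccc(NC(=O)N3CCOCC3)c2)cc1` is not yet measured. It differs from compound 2 by morpholin-4-yl in place of benzyloxy on a carbonyl carbon. Within the data shown here, the only measured step, a number 19 percentage points lower from compound 1 to compound 2 (beyond the scatter), concerns a different part of the molecule and gives no direct guide to this change, so no step beyond the scatter is predicted with confidence. Compound 3 is estimated at 45% (range 20% to 70%). That estimate means a step of a number 5 percentage points lower from compound 2 to compound 3 (within the scatter).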

Compound 3, a percentage reported as inhibition, at one concentration (the size of the read-out at that concentration, not a potency): 31%
Compound 3: the middle estimate sits 14 percentage points above what was measured; low and high end bracket the measured number.
By their numbers in this assay, from the lowest: compound 3; then compound 2; then compound 1.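

In this assay, morpholin-4-yl on the carbonyl carbon gives a number 19 percentage points lower from compound 2 to compound 3 (beyond the scatter) and a number 38 percentage points lower from compound 1 to compound 3 (beyond the scatter), so this position also responds when the group is joined through nitrogen rather than oxygen. Of the three groups compared here, morpholin-4-yl, the only one joined through nitrogen, gives the lowest number, with both steps beyond the scatter. No available evidence accounts for these steps.

Open, on these data alone, is whether piperidin-1-yl, which has no ring oxygen, or a diethylamino group would read like morpholin-4-yl, and so whether the ring oxygen matters at this position.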